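The source may hold more compounds than are shown below. What is called first, only, known or untested is meant among the compounds shown, and "the series" means these compounds.

Compound 1, `C/C(=N\NC(=S)Nc1ccccc1Cl)c1ccccn1`, gives 2.6 nM in a functional assay on U-87MG ATCC cells (Homo sapiens) for cytotoxicity, read by MTT assay, with a stated time of 48 h; a lower number here means a stronger inhibitor, a higher number a weaker inhibitor.
Compound 2, `C/C(=N\NC(=S)Nc1ccccc1F)c1ccccn1`, gives 5 nM in this assay.
Compound 3, `CC(=NNC(=S)Nc1ccc(Cl)cc1)c1ccccn1`, gives 1.7 nM in this assay.

Compound 4, `CC(=NNC(=S)Nc1ccc(F)cc1)c1ccccn1`, has not yet been measured. It differs from compound 3 by fluoro in place of chloro on an aromatic carbon. The same kind of change is seen between compound 1 and compound 2, where it is fluoro in place of chloro on an aromatic carbon; the surroundings differ, since in the measured pair the place is ortho to a large group and in the new pair it is para to a large group. In this assay that measured change gave a 1.9-fold higher number from compound 1 to compound 2 (0.28 log units; within the scatter). How the core of compound 3 differs from the core of compound 1 is not broken down here; the two values show that compound 3 sits within the scatter of compound 1 and beyond it from compound 2.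

Among the compounds with values here, since the only measured example of this change is a 1.9-fold higher number from compound 1 to compound 2 (0.28 log units; within the scatter), a step of about that size is expected from compound 3. Compound 4 is therefore expected to give 3.3 nM in this assay, most likely between 1.5 nM and 7 nM. This estimate means a step of a 1.9-fold higher number from compound 3 to compound 4 (0.29 log units; within the scatter).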

Compound 4, half-maximal inhibitory concentration: 10 nM
Compound 4: middle estimate off by 3.0-fold (0.48 log units), on the low side, and the stated range ends below it.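

In this assay, fluoro in place of chloro on an aromatic carbon, para to a large group, gives a 5.9-fold higher number from compound 3 to compound 4 (0.77 log units; beyond the scatter). The size of this change therefore did not carry over from one core to the other, although the number rose in both pairs: the same change on two cores in this assay, a 1.9-fold higher number (0.28 log units; within the scatter) from compound 1 to compound 2 and a 5.9-fold higher number (0.77 log units; beyond the scatter) from compound 3 to compound 4, 3.1-fold (0.49 log units) apart, beyond the scatter of two such steps. Within the data shown here, with only one pair on each core, this does not show what sets the size of the step, nor does it fix a general size for the change across the series.

The compounds shown leave open how other groups at the same place would read, such as bromo, methyl, methoxy or trifluoromethyl, and whether any of them would follow either of the two steps. They also leave open how a carbonyl in place of the thiocarbonyl, or an ethyl group in place of the methyl on the imine carbon, would read in this series.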